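The compounds below may be only part of what the source reports. "The series", "measured", "known", "first", "only" and "open" are said of these compounds alone.

Values measured so far in a physicochemical assay for lipophilicity, using the shake flask method, in phosphate buffer, measured as octanol-water partition, with a stated time of 24 h, at pH 7.4 (a lower number here means a more polar compound, a higher number a more lipophilic compound), are:

compound 1 `O=S1(=O)CC(c2cccc(F)c2)c2c(C3CC3)nn(-c3ccccc3F)c2O1` gives 2.86
compound 2 `Cc1nn(-c2ccccc2F)c2c1C(c1ccc(F)cc1)CS(=O)(=O)O2` gives 2.13
compound 3 `COc1ccc(-c2nn(-c3ccccc3Cl)c3c2CCS(=O)(=O)O3)cc1` gives 3.04

Compound 1 cannot be told apart from compound 3, since the two lie within the scatter of each other, while compound 2 sits lower, beyond the scatter. Compound 4 `Cc1cc(C2CS(=O)(=O)Oc3c2c(C2CC2)nn3-c2ccccc2F)ccc1Br` has 4-bromo-3-methylphenyl in place of 3-fluorophenyl on a saturated ring carbon, a change counted as 4-bromo-3-methylphenyl in place of 3-fluorophenyl on a saturated ring carbon and not yet tested. Among the measured compounds shown here, no measured pair shows a step of this kind, so the expectation is a judgement from the swap alone. A rise beyond the scatter in this assay is expected, with a number 0.94 log units higher from compound 1 to compound 4 (beyond the scatter) as the estimated step. For compound 4 the estimated value is 3.8 within an expected range of 3.3 to 4.3 on this scale.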

Compound 4, partition coefficient: 2.72
Estimate against measurement, compound 4: 1.08 log units above, outside the stated range (below it).
By their numbers in this assay, from the lowest: compound 2; then compounds 4, 1 and 3 (each within the scatter of the next, the first and the last beyond it).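

In this assay, placing 4-bromo-3-methylphenyl in place of 3-fluorophenyl on a saturated ring carbon gives a number 0.14 log units lower from compound 1 to compound 4 (within the scatter) on the core of compound 1. Among the compounds shown here, this is the first single-place comparison, and at this position the two groups cannot be told apart by this measurement. Nothing available explains why the two numbers stay so close.

Going by these compounds, whether an amine or a carboxylic acid on this saturated ring carbon would move the number beyond the scatter remains open. So does whether this swap would give a similar result on a different core.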